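The compounds below may be only part of what the source reports. "The series", "measured", "known", "first", "only" and "open" are said of these compounds alone.

Three compounds have been measured in a functional assay on HeLa cells (Homo sapiens) for cytotoxicity, read by sulforhodamine B assay; a lower number here means a stronger inhibitor, a higher number a weaker inhibitor:

compound 1, `Cc1ccc(S(=O)(=O)NC(C2=CC(=O)c3c(O)ccc(O)c3C2=O)C(C)C)cc1`, gives 4850 nM
compound 2, `COc1ccc(S(=O)(=O)NC(C2=CC(=O)c3c(O)ccc(O)c3C2=O)C(C)C)cc1`, gives 8950 nM
compound 3, `COc1ccc(S(=O)(=O)NC(C2=CC(=O)c3c(O)ccc(O)c3C2=O)C(C)C)c(OC)c1`, gives 2750 nM

Compound 3 has the lowest of the three numbers. Its nearest neighbour is compound 1, and the step of a 1.8-fold lower number from compound 1 to compound 3 (0.25 log units; within the scatter) lies within the scatter, so those two cannot be ordered. Its furthest neighbour is compound 2, and the step of a 3.3-fold lower number from compound 2 to compound 3 (0.51 log units; beyond the scatter) is beyond the scatter, though modest.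

Compound 4, `CCOC(=O)c1ccc(S(=O)(=O)NC(C2=CC(=O)c3c(O)ccc(O)c3C2=O)C(C)C)cc1`, differs from compound 3 only at the group on the sulfonyl sulfur: 4-(ethoxycarbonyl)phenyl in place of 2,4-dimethoxyphenyl on a sulfonyl sulfur

All three measured steps concern the same position and therefore bear on this change. The step of a 1.8-fold higher number from compound 1 to compound 2 (0.27 log units; within the scatter) stayed within the scatter, as did a 1.8-fold lower number from compound 1 to compound 3 (0.25 log units; within the scatter), and only a 3.3-fold lower number from compound 2 to compound 3 (0.51 log units; beyond the scatter) exceeded it, modestly. Every swap of the aryl group on the sulfonyl sulfur so far has moved the number by no more than a modest amount. Since compound 3 holds the lowest number, the estimate for compound 4 is a somewhat higher number, a step of a 1.8-fold higher number from compound 3 to compound 4 (0.26 log units; within the scatter), which may fall within the scatter. Compound 4 is expected to give about 5000 nM in this assay, with a range from 2000 nM to 12500 nM.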

Compound 4, half-maximal inhibitory concentration: 850 nM
Compound 4: the middle estimate sits 5.9-fold (0.77 log units) above what was measured; the whole stated range lies above it.
By their numbers in this assay, from the lowest: compound 4; then compounds 3, 1 and 2 (each within the scatter of the next, the first and the last beyond it).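

In this assay the group on the sulfonyl sulfur turns out to be able to move the number much further than the earlier swaps suggested: an 11-fold lower number from compound 2 to compound 4 (1.02 log units; beyond the scatter) is a large step, the first of that size among these compounds. The other two steps, a 5.7-fold lower number from compound 1 to compound 4 (0.76 log units; beyond the scatter) and a 3.2-fold lower number from compound 3 to compound 4 (0.51 log units; beyond the scatter), are modest but also beyond the scatter, so compound 4 holds the lowest number of the four. Among the aryl groups shown, 4-(ethoxycarbonyl)phenyl is thus the only one that stands clearly apart from all the others, whereas 4-methylphenyl and 2,4-dimethoxyphenyl cannot be ordered against each other.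

Going by these compounds, whether this gain belongs to the whole ethoxycarbonyl group, to its carbonyl or to its ethyl chain remains open, and a carboxylic acid, a methyl ester or a primary amide in its place would speak to that question. Nothing in the data gives a measured reason for the lower number of compound 4.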